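Methyl to isopropyl on the anilide ring: cytotoxicity notes

The source may hold more compounds than are shown below. What is called first, only, known or untested is meant among the compounds shown, and "the series" means these compounds.

Measured so far in an ADME assay on Huh-7 cells (Homo sapiens) for cytotoxicity, read by MTT assay, with a stated time of 72 h; a higher number here means that more compound is tolerated, a lower number that less compound is tolerated:
- compound 1 `C/C(=C\c1c[nH]c2cc(C)ccc12)C(=O)Nc1ccc(C(C)(C)C)cc1` gives 25600 nM
- compound 2 `C/C(=C\c1c[nH]c2cc(C(C)C)ccc12)C(=O)Nc1ccc(C(C)(C)C)cc1` gives 24800 nM
- compound 3 `C/C(=C\c1c[nH]c2ccc(C#N)cc12)C(=O)Nc1ccc(C)cc1` stands at > 100000 nM, which is a limit of the assay and not a number

Compound 1 and compound 2 share a core and differ in one place, (isopropyl in place of methyl on an aromatic carbon). The step there is a 1.0-fold lower number from compound 1 to compound 2 (0.01 log units; within the scatter).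

Compound 3 carries a different core; the difference between the core of compound 1 and the core of compound 3 is not broken down here.

Compound 4 `C/C(=C\c1c[nH]c2ccc(C#N)cc12)C(=O)Nc1ccc(C(C)C)cc1` is not yet measured. It stands to compound 3 as compound 2 stands to compound 1: isopropyl in place of methyl on an aromatic carbon. This is the same kind of change as from compound 1 to compound 2, not the same one, since the place differs. From compound 1 to compound 2 the group sits on an aromatic carbon of a six-membered aromatic ring of carbon only, part of a fused or bridged system of two rings, meta to a fused ring and para to a fused ring; from compound 3 to compound 4 it sits on an aromatic carbon of a six-membered aromatic ring of carbon only, para to a large group.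

In this assay the step from compound 3 to compound 4 is expected to be a number no higher from compound 3 to compound 4 (the limit leaves the size open), resting on the step from compound 1 to compound 2, a 1.0-fold lower number from compound 1 to compound 2 (0.01 log units; within the scatter), and on the limit at which compound 3 sits, (the limit of > 100000 nM in this assay, at which 1 of the 3 values shown sits). Compound 4 is therefore estimated at 100000 nM, between 40000 nM and 300000 nM, and a limit rather than a number is expected to be the likelier outcome.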

Compound 4, half-maximal cytotoxic concentration: 137000 nM
For compound 4 the middle estimate is 1.4-fold (0.14 log units) below the measured one; the measured number falls inside the stated range.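

Among the compounds shown here, no step from compound 3 to compound 4 can be read in this assay, because compound 3 stands at a limit of the assay and not at a number: the limit of > 100000 nM in this assay, at which 1 of the 4 values shown sits.

The compounds shown leave open how far isopropyl in place of methyl, para to a large group, moves the tolerated concentration on the core of compound 3, since no pair on that core has two numbers.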